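A few compounds are considered here, and "the series" means these few. Any claim that something is new, unique, unknown or untested is made for them only; others in the source may bear on it.

The compounds measured so far in a physicochemical assay for solubility, in phosphate buffer, measured as kinetic solubility (on this read-out higher numbers stand for higher solubility and lower numbers for lower solubility), are:

Compound 1 `C/C(=C1/OC(=O)NC1=O)C(c1ccc(-c2ccc3cccc(F)c3c2)[nH]c1=O)C(C)C`, giving 17200 nM
Compound 2 `CC(C)[C@@H](c1ccc(-c2ccc3cccc(F)c3c2)[nH]c1=O)[C@H]1OC(=O)NC1=O`, giving 31600 nM
Compound 3 `CC(C)[C@H](C[C@@H]1OC(=O)NC1=O)c1ccc(-c2ccc3cccc(F)c3c2)[nH]c1=O`, giving 21100 nM

The three numbers lie close together. Compound 1 has the smallest of them, but its gap to compound 3 and its gap to compound 2 are each within the usual scatter of this assay, so the three compounds cannot be told apart on this read-out. Going by the values given here, the only single-point step among the measured set is a 1.5-fold lower number from compound 2 to compound 3 (0.18 log units; within the scatter), which is itself within the scatter.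

Compound 4 `CC(C)C(c1ccc(-c2ccc3cccc(F)c3c2)[nH]c1=O)C1NC(=O)NC1=O` is not yet measured. It differs from compound 1 at one place: a group of 7 heavy atoms (3 carbon, 2 nitrogen, 2 oxygen; one five-membered non-aromatic ring with 2 hetero atoms) in place of a group of 9 heavy atoms (5 carbon, 1 nitrogen, 3 oxygen; one five-membered non-aromatic ring with 2 hetero atoms), on a saturated chain carbon bound to an aromatic carbon and a saturated chain carbon. Among the compounds with values here, no measured pair shows this particular exchange, so nothing among the three compounds bears directly on it; what the set does show is that three different groups at this position all give numbers within the scatter of one another. On that basis, no step beyond the scatter is expected, and the estimated 1.3-fold higher number from compound 1 to compound 4 (0.11 log units; within the scatter) reflects that. Compound 4 is therefore expected to give about 22000 nM in this assay, with a likely range from 9000 nM to 50000 nM.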

Compound 4, solubility: 10600 nM
Compound 4: the middle estimate sits 2.1-fold (0.32 log units) above what was measured; the range from low to high includes it.
By their numbers in this assay, from the lowest: compounds 4, 1, 3 and 2 (each within the scatter of the next, the first and the last beyond it).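

Going by these compounds alone, the change is the first at this place to separate two compounds in this assay. On its own it stays small, with a 1.6-fold lower number from compound 1 to compound 4 (0.21 log units; within the scatter), so the 2,5-dioxoimidazolidin-4-yl group, with its 2 hydrogen-bond donors and 2 hydrogen-bond acceptors, cannot be told apart from the group it replaces. Set against the other end of the series, however, compound 4 at 10600 nM and compound 2 at 31600 nM lie beyond the scatter of each other, so the groups at this saturated chain carbon no longer all fall within the scatter, though compounds 1 and 3 still sit within it of both. Nothing shown here gives a measured reason for this gap between the two five-membered rings.

The compounds shown leave open how a group without a five-membered ring, such as a carboxylic acid, an amine or a simple amide, would read at this place. They also leave open whether a longer chain linking the 2,5-dioxoimidazolidin-4-yl ring to this carbon would give a number like that of compound 4, and whether its stereochemistry matters.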